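This account rests on a few compounds, and the source may have more. Where it says the series, first, only, none or still open, it means among the compounds named here.

Measured compounds in a physicochemical assay for solubility, at pH 2; on this read-out lower numbers stand for lower solubility and higher numbers for higher solubility:
compound 2 `CN(C)CCCNc1nc(N)nc2cc(-c3ccc(C(F)(F)F)cc3)sc12`, 210 ug/mL
compound 3 `Nc1nc(NC2CCCNC2)c2sc(-c3ccc(C(F)(F)F)cc3)cc2n1`, 125 ug/mL
compound 1 `CNc1nc(N)c2sc(-c3ccc(C(F)(F)F)cc3)cc2n1`, a limit of the assay, > 100 ug/mL

Among the two plain numbers, compound 3 holds the lower one in this assay, and the single measured step, a 1.7-fold lower number from compound 2 to compound 3 (0.23 log units; within the scatter), lies within the scatter. Compound 4 `Nc1nc(NC2CCOCC2)c2sc(-c3ccc(C(F)(F)F)cc3)cc2n1` differs from compound 3 by oxan-4-yl in place of piperidin-3-yl on a nitrogen on an aromatic ring. For the measured compounds named here, no measured step makes this exchange: the one step at hand swaps one amine-bearing group for another, and compound 1 contributes only a limit (the limit of > 100 ug/mL in this assay, at which 1 of the 3 values shown sits). Going by the values given here, with the basic ring nitrogen gone and no measured counterpart, the expectation is a moderate fall, a 2.5-fold lower number from compound 3 to compound 4 (0.40 log units; beyond the scatter). Compound 4 is estimated at 50 ug/mL in this assay, with a range from 12 ug/mL to 200 ug/mL.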

Compound 4, solubility: < 5 ug/mL
Compound 4 was reported as a limit; the forecaster's own chance of this, stated with the estimate: 20%; at least 10-fold (1.00 log units) between middle value and limit.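

In this assay, oxan-4-yl on this nitrogen gives an at least 25-fold lower number from compound 3 to compound 4 (1.39 log units; beyond the scatter), and the same group gives an at least 42-fold lower number from compound 2 to compound 4 (1.62 log units; beyond the scatter), whereas the earlier exchange of one amine-bearing group for another stayed within the scatter. Both of these steps rest on a limit for compound 4: the limit of < 5 ug/mL in this assay, at which 1 of the 4 values shown sits. Compound 1, which has no ring on this nitrogen, holds a limit of its own, > 100 ug/mL, so loss of the ring nitrogen alone makes no general rule.

On these data alone, whether the fall follows the oxygen or the point of attachment stays open: piperidin-4-yl and oxan-3-yl in this place would separate the two. As far as these compounds go, the true number for compound 4 also stays open.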